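The compounds below may be only part of what the source reports. "The series", "measured", "known", "first", "only" and "open" are said of these compounds alone.

Measured so far:
- compound 1, `CC(C)CN1C(=O)c2ccccc2[C@H](C(=O)Nc2cccc(C#N)c2)[C@H]1c1cccs1`: in an ADME assay on microsomes from liver (Mus musculus, strain CD-1) for metabolic stability, read by HPLC, using NADPH, with a stated time of 4 h (a lower number here means slower removal, a higher number faster removal of the compound), compound 1 gives 195 mL/min/kg
- compound 2, `CC(C)CN1C(=O)c2ccccc2[C@H](C(=O)Nc2ccc(F)c(C#N)c2)[C@H]1c1ccc(C#N)s1`: in this assay compound 2 gives 44.7 mL/min/kg

Of these two numbers, compound 2 has the lower one, and the gap to compound 1 lies beyond the usual scatter of this kind of measurement. Compound 3, `CC(C)CN1C(=O)c2ccccc2[C@H](C(=O)Nc2ccc(F)c(C#N)c2)[C@H]1c1cn[nH]c1`, has not yet been measured. It differs from compound 2 in one place: 1H-pyrazol-4-yl in place of 5-cyanothiophen-2-yl on a saturated ring carbon. Among the compounds with values here, no measured pair in this set shows the same change, so the direction of this step has to be guessed from the two numbers at hand. Compound 3 is expected to give 35 mL/min/kg, with a likely range from 12 mL/min/kg to 100 mL/min/kg. This estimate means an expected step of a 1.3-fold lower number from compound 2 to compound 3 (0.11 log units; within the scatter), a modest move downward that may well stay within the scatter; a clear rise back toward the value of compound 1 seems less likely.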

Compound 3, clearance: 162 mL/min/kg
Compound 3: the middle estimate sits 4.6-fold (0.67 log units) below what was measured, outside the stated range (above it).
By their numbers in this assay, from the lowest: compound 2; then compounds 3 and 1 (each within the scatter of the next).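

In this assay, the group on this saturated ring carbon matters on its own: with the rest of the molecule unchanged, 1H-pyrazol-4-yl in place of 5-cyanothiophen-2-yl gives a 3.6-fold higher number from compound 2 to compound 3 (0.56 log units; beyond the scatter). The earlier pair, compound 1 and compound 2, differs in more than one place, so it could not isolate the contribution of this position. Compound 2 and compound 3 share everything else, so that shared part alone does not keep the number low, and the group at this position can decide whether removal is slow or fast.

The data shown give no measured reason for this rise. Also open, from the compounds shown here alone, is how other groups on this carbon would behave, such as a carboxylic acid or a morpholine ring.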